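Working notes: fluoro in place of cyclopropyl

The source may hold more compounds than are shown below. What is called first, only, known or untested is meant among the compounds shown, and "the series" means these compounds.

Of the compounds shown here, three have numbers so far in a functional assay on HOS-TE85 cells (Homo sapiens) for inhibition, read by CCK-8 assay, with a stated time of 72 h; a lower number here means a stronger inhibitor, a higher number a weaker inhibitor. Compound 3 `COc1ccccc1N1C(=O)CSC1c1cc(C(=O)NCCCCc2ccccc2)cc(C2CC2)c1` gives 23.5 nM and sits within the scatter of compound 1 `Cc1ccnc(N2C(=O)CS[C@@H]2c2cccc(C(=O)NCCCCn3cccn3)c2)c1` at 21.9 nM. Together they stand at the stronger end of the three numbers. Compound 2 `CC1SC(c2cccc(C(=O)NCCCCc3ccccc3)c2)N(c2ccc(C3CC3)cc2)C1=O` gives 191 nM and lies beyond the scatter on the weaker side of compound 3.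

Compound 4 `COc1ccccc1N1C(=O)CSC1c1cc(F)cc(C(=O)NCCCCc2ccccc2)c1` differs from compound 3 in one place: fluoro in place of cyclopropyl on an aromatic carbon.

Among the compounds with values here, no measured pair isolates this change, so the series gives no direct size for it. Compound 1 carries no cyclopropyl on that ring and still gives 21.9 nM, which argues against a large loss, although it differs from compound 3 elsewhere too. A small weakening in this assay is expected, close to the scatter. The estimated step is a 1.6-fold higher number from compound 3 to compound 4 (0.21 log units; within the scatter). For compound 4 the expected value is 38 nM. The estimated range runs from 12 nM to 120 nM.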

Compound 4, half-maximal inhibitory concentration: 40.9 nM
Estimate against measurement, compound 4: 1.1-fold (0.03 log units) below; measured number inside the range.
By their numbers in this assay, from the lowest: compounds 1, 3 and 4 (each within the scatter of the next); then compound 2.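

In this assay, this pair gives the first direct measure at this position: a 1.7-fold higher number from compound 3 to compound 4 (0.24 log units; within the scatter). Exchanging cyclopropyl for fluoro on this aromatic carbon therefore leaves the number within the scatter, so the two groups cannot be ranked here. Despite the difference in size, with a three-membered carbon ring leaving and a single fluorine entering, the shared scaffold keeps its activity in this assay, and no available measurement gives a cause for this.

From the compounds shown here alone, it remains open whether this carbon accepts an amine, a carboxylic acid or a longer alkyl chain as readily as cyclopropyl and fluoro. A plain hydrogen at this position, with the rest of compound 3 unchanged, would show whether either group contributes to the activity at all.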